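The compounds below may be only part of what the source reports. "The series", "measured", "known", "first", "only" and "open" are said of these compounds alone.

Working notes on the series. Two compounds of the shared core carry a measurement in a functional assay on HCT-116 cells (Homo sapiens) for cytotoxicity, read by MTT assay, with a stated time of 72 h; a lower number here means a stronger inhibitor, a higher number a weaker inhibitor. Compound 1 `Cc1c(/N=C/c2ccc(N(C)C)cc2)c(=O)n(-c2ccccc2)n1C` gives 832000000 nM in this assay. Compound 2 `COc1ccccc1/C=N/c1c(C)n(C)n(-c2ccccc2)c1=O` gives 324000000 nM in this assay, which is the lower of the two numbers, and the gap from compound 1 to compound 2 lies beyond the usual scatter. Both numbers are very high, so neither compound is a strong inhibitor. Compound 3 `Cc1c(/N=C/c2cccc(Cl)c2)c(=O)n(-c2ccccc2)n1C` is not yet measured; it differs from compound 2 by 3-chlorophenyl in place of 2-methoxyphenyl on a carbon with a double bond to nitrogen. Among the compounds with values here, no measured pair shows a step of this kind, so the effect of trading one substituted phenyl for another has no precedent here. With both measured numbers sitting so high, the expected step from compound 2 to compound 3 is a 1.2-fold higher number from compound 2 to compound 3 (0.09 log units; within the scatter), that is, no shift beyond the scatter in either direction. Compound 3 is therefore estimated at 400000000 nM in this assay, with a range from 120000000 nM to 1300000000 nM.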

Compound 3, half-maximal inhibitory concentration: 912000000 nM
For compound 3 the middle estimate is 2.3-fold (0.36 log units) below the measured one; the measured number falls inside the stated range.
By their numbers in this assay, from the lowest: compound 2; then compounds 1 and 3 (each within the scatter of the next).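

At the aryl group on a carbon with a double bond to nitrogen, replacing 2-methoxyphenyl with 3-chlorophenyl gives a 2.8-fold higher number from compound 2 to compound 3 (0.45 log units; beyond the scatter) in this assay. Within the data shown here, this is the first one-place step readable, and it shows that the number at this position responds to the change of substituted phenyl, though only modestly and with compound 3 still at a very high number. Nothing available explains this step.

The step changes the substituent and its place on the phenyl together, and the compounds shown do not separate the two. They also leave open whether a carboxylic acid or a morpholine on the phenyl, or an alkyl chain in place of the phenyl, would bring the number far below this very high range.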